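Fluoro to Hydroxypropyl on a Fused Aromatic Ring

The source may hold more compounds than are shown below. What is called first, only, known or untested is meant among the compounds shown, and "the series" means these compounds.

Of the compounds shown here, two built on a shared core have so far been tested in an assay on isolated protein for inhibition of long-chain fatty acid transport protein 1 (Mus musculus); a higher number here means a weaker inhibitor, a lower number a stronger inhibitor. Compound 1 `CCn1c(CNc2ccccc2)nnc1SCC(=O)Nc1ccc(C(=O)NC)cc1` returns only a limit of the assay in this assay, namely > 10000 nM, and not a number. Compound 2 `CCn1c(CNc2ccccc2)nnc1SCc1nc2cc(F)ccc2o1` gives 7800 nM in this assay. Among the compounds with values here, compound 2 therefore holds the only actual number in the set, because the other result sits at the limit described as the limit of > 10000 nM in this assay, at which 1 of the 2 values shown sits. Within the data shown here, no step between measured compounds that differ in a single place can be drawn here; the two results show only that compound 2 yields a number where compound 1 does not.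

Compound 3 `CCC(O)c1ccc2oc(CSc3nnc(CNc4ccccc4)n3CC)nc2c1` remains to be measured. Its difference from compound 2 is counted as 1-hydroxypropyl in place of fluoro on an aromatic carbon. Among the measured compounds shown here, with no measured step of comparable kind to lean on, the change from compound 2 to compound 3 is expected to be modest, a 1.3-fold lower number from compound 2 to compound 3 (0.11 log units; within the scatter), and not clearly beyond the usual scatter in either direction. Compound 3 is accordingly expected to give about 6000 nM in this assay, with a plausible range from 2000 nM to 20000 nM.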

Compound 3, half-maximal inhibitory concentration: 3700 nM
The estimate for compound 3 lay 1.6-fold (0.21 log units) above the measured number, and the stated range covers the measured number.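

Within the data shown here, the first step that can be read at this position runs in this assay as a 2.1-fold lower number from compound 2 to compound 3 (0.32 log units; beyond the scatter), and it is modest but beyond the scatter. It shows that the aromatic carbon of the six-membered ring, meta to a fused ring and para to a fused ring, accepts a change from a single fluoro atom to the branched 1-hydroxypropyl group, which brings a hydrogen-bond donor and acceptor, without the number rising or the result being lost to the assay limit. The two earlier compounds could not show this, as they differ in more than one place, and compound 1 remains the only result without a number, a limit of the assay: the limit of > 10000 nM in this assay, at which 1 of the 3 values shown sits.

The compounds shown leave open whether the hydroxyl or the carbon chain of the 1-hydroxypropyl group accounts for the step, a question that a plain propyl group at the same carbon would address. They also leave open how a longer chain, an amine or a carboxylic acid at this carbon would read in this assay, and so whether the step is the start of a trend or a single result.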